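Swapping 4-chlorobenzyl for acetyl

A few compounds are considered here, and "the series" means these few. Any claim that something is new, unique, unknown or untested is made for them only; others in the source may bear on it.

Of the compounds shown here, two have been measured so far. In a physicochemical assay for solubility, with a stated time of 3 days, at pH 2 (on this read-out lower numbers stand for lower solubility and higher numbers for higher solubility), compound 1 `NC(=O)c1ccc2[nH]c(-c3ccc(OCC4CCNCC4)cc3)nc2c1` gives > 400000 nM as a limit of the assay and not a number. Among the measured compounds shown here, compound 2 `NC(=O)c1ccc2[nH]c(-c3ccc(OCCC4CCN(Cc5ccc(Cl)cc5)CC4)cc3)nc2c1` gives 179000 nM and is the only true number in hand. Compound 3 `CC(=O)N1CCC(CCOc2ccc(-c3nc4cc(C(N)=O)ccc4[nH]3)cc2)CC1` differs from compound 2 by acetyl in place of 4-chlorobenzyl on an amine nitrogen in a ring, a change counted as acetyl in place of 4-chlorobenzyl on an amine nitrogen in a ring in full. For the measured compounds named here, no step between measured compounds is available to size this change, so the expectation rests on the structural change and on compound 2 at 179000 nM alone. A modest rise in this assay is expected, possibly no larger than the usual scatter. The estimated shift is a 1.6-fold higher number from compound 2 to compound 3 (0.19 log units; within the scatter) for this pair. For compound 3 the estimated value is 280000 nM within an expected range of 90000 nM to 400000 nM across repeated measurements.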

Compound 3, solubility: 87000 nM
Compound 3: the middle estimate sits 3.2-fold (0.51 log units) above what was measured, outside the stated range (below it).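

In this assay, among the compounds shown here, the step of a 2.1-fold lower number from compound 2 to compound 3 (0.31 log units; beyond the scatter) gives the first sized change on this amine nitrogen in a ring, and it shows that acetyl in place of 4-chlorobenzyl does not bring a higher number, even though the aromatic ring leaves and a hydrogen-bond acceptor enters. The second step, an at least 4.5-fold lower number from compound 1 to compound 3 (0.66 log units; beyond the scatter), sets (1-acetylpiperidin-4-yl)methyl in place of piperidin-4-yl and points the same way, towards a lower number for the acetyl compound. Compound 1 stands at a limit of the assay and not at a number, so this second step gives only a smallest size: the limit of > 400000 nM in this assay, at which 1 of the 3 values shown sits.

From the compounds shown here alone, it remains open where a plain benzyl, a methyl or a methanesulfonyl on this nitrogen would fall relative to compound 2 and compound 3. Going by these compounds, it also remains open whether a urea would behave as acetyl does here.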